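Fluoro for methyl on the fused ring of compound 2

A few compounds are considered here, and "the series" means these few. Any claim that something is new, unique, unknown or untested is made for them only; others in the source may bear on it.

Compound 2 `Cc1cc(C)cc(S(=O)(=O)c2cnc3ccc(C)cc3c2N2CCC(C)CC2)c1` gives 80% in an assay on isolated protein for displacement of a labelled ligand from metabotropic glutamate receptor 5 (Homo sapiens), with a stated time of 60 min, tested at 1 uM (on this read-out lower numbers stand for less inhibition and higher numbers for more inhibition at the one concentration tested (going by the name of the read-out)), the higher of the two numbers measured, with compound 1 `CC1CCN(c2c(S(=O)(=O)c3cc(Cl)cc(Cl)c3)cnc3ccc(F)cc23)CC1` at 69% standing beyond the scatter below it. Compound 3 `Cc1cc(C)cc(S(=O)(=O)c2cnc3ccc(F)cc3c2N2CCC(C)CC2)c1` carries the change fluoro in place of methyl on an aromatic carbon while keeping the rest of compound 2 unchanged. Among the compounds with values here, no directly comparable step between measured compounds exists for this exchange, so a small shift, most likely within the scatter and tending slightly downward, is expected in this assay. Compound 3 is therefore estimated at 74% in this assay, with a range from 58% to 88%, an expected step of a number 6 percentage points lower from compound 2 to compound 3 (within the scatter).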

Compound 3, a percentage reported as inhibition, at one concentration (the size of the read-out at that concentration, not a potency): 83%
For compound 3 the middle estimate is 9 percentage points below the measured one; low and high end bracket the measured number.
By their numbers in this assay, from the lowest: compound 1; then compounds 2 and 3 (each within the scatter of the next).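

In this assay, fluoro in place of methyl on this aromatic carbon gives a number 3 percentage points higher from compound 2 to compound 3 (within the scatter), so the exchange leaves the read-out within the scatter. Within the data shown here, with fluoro held fixed, 3,5-dimethylphenyl in place of 3,5-dichlorophenyl on the sulfonyl sulfur gives a number 14 percentage points higher from compound 1 to compound 3 (beyond the scatter), so of the two places in which compound 1 and compound 2 differ, the sulfonyl substituent is the one with a step beyond the scatter. Nothing available explains either step. From the compounds shown here alone, whether chloro, methoxy or a nitrile on this aromatic carbon would read alike stays open. So does whether the sulfonyl step holds with methyl on the fused ring.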